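A few compounds are considered here, and "the series" means these few. Any claim that something is new, unique, unknown or untested is made for them only; others in the source may bear on it.

Of the compounds shown here, three share one core and have been tested in a functional assay on MCF7 cells (Homo sapiens) for inhibition, read by MTT assay, with a stated time of 48 h; on this read-out higher numbers stand for weaker inhibition and lower numbers for stronger inhibition. Compound 1 `COc1ccc(CN(c2cc(OC)c(OC)c(OC)c2)S(=O)(=O)c2ccccc2)cc1` gives only a limit of the assay, > 50000 nM, which is a limit and not a number (the limit of > 50000 nM in this assay, at which 1 of the 3 values shown sits). Compound 2 `COc1ccc(CN(c2cc(OC)c(OC)c(OC)c2)S(=O)(=O)c2ccc(C(C)(C)C)cc2)cc1` gives 32700 nM in this assay, and the change from compound 1 to compound 2 is an at least 1.5-fold lower number from compound 1 to compound 2 (0.18 log units; that floor lies within the scatter). Compound 3 `COc1cc(N(Cc2ccc(Cl)cc2)S(=O)(=O)c2ccc(C)cc2)cc(OC)c1OC` gives 18600 nM in this assay; its number and that of compound 2 sit within the scatter of one another, so no order between them can be read.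

Compound 4 `COc1cc(N(Cc2ccc(Br)cc2)S(=O)(=O)c2ccc(C)cc2)cc(OC)c1OC` differs from compound 3 by bromo in place of chloro on an aromatic carbon. Going by the values given here, no measured step involves a swap of one halogen for another; the only measured step, from compound 1 to compound 2, concerns a different group at a different ring, so it does not bear on this change. With nothing pointing either way, the expected change from compound 3 to compound 4 is a 1.1-fold lower number from compound 3 to compound 4 (0.04 log units; within the scatter), none beyond the scatter. Compound 4 is therefore estimated at 17000 nM in this assay, within 7000 nM to 45000 nM.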

Compound 4, half-maximal inhibitory concentration: 10900 nM
Compound 4: middle estimate off by 1.6-fold (0.19 log units), on the high side, and the stated range covers the measured number.
By their numbers in this assay, from the lowest: compounds 4, 3 and 2 (each within the scatter of the next, the first and the last beyond it). At a limit, above all of these: compound 1.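

Going by these compounds alone, this is the first measured change at the 4-chlorobenzyl end of the molecule, on the aromatic carbon para to a large group; earlier steps concerned a different ring. In this assay, the exchange of chloro for bromo gives a step (a 1.7-fold lower number from compound 3 to compound 4 (0.23 log units; within the scatter)) that stays within the scatter, so no order can be read between the two halogens, and this place accepts either one without a change that can be told from repeat measurement. Nothing in the data available here accounts for the size of this step.

Two halogens at one place say little about how much this position can matter. Going by these compounds, whether fluoro, a nitrile, an amine or a carboxylic acid on the same carbon would move the number beyond the scatter remains open, in either direction.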